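From Phenyl to Methyl on the Amide Nitrogen

A few compounds are considered here, and "the series" means these few. Any claim that something is new, unique, unknown or untested is made for them only; others in the source may bear on it.

Compound 1 `O=C(c1c(O)ccc2cc(-c3cccc(O)c3)ccc12)N1CCOCC1`: 62%
Compound 2 `O=C(Nc1ccccc1)c1c(O)ccc2cc(-c3cccc(O)c3)ccc12`: 80%
Compound 3 `O=C(Nc1ccccc1)c1cc2cc(-c3cccc(O)c3)ccc2cc1O`: 62%

In an in vitro assay on Sf9 cells for inhibition of 17-beta-hydroxysteroid dehydrogenase type 1 (Homo sapiens), tested at 1 uM (on this read-out higher numbers stand for a stronger effect at the one concentration tested and lower numbers for a weaker effect), compound 3 gives 62%, the same number as compound 1 within the usual scatter; together they are the two lowest of the three, while compound 2 sits higher by a margin beyond the scatter. Compound 4 `CNC(=O)c1cc2cc(-c3cccc(O)c3)ccc2cc1O` differs from compound 3 in one place: methyl in place of phenyl on an amide-type nitrogen. Going by the values given here, the one measured step that touches the group carried by the carbonyl is a number 18 percentage points higher from compound 1 to compound 2 (beyond the scatter), where a larger nitrogen substituent went with a higher number. Among the compounds with values here, replacing phenyl with methyl on the amide nitrogen runs the other way, so a modest fall is expected, though no step of exactly this kind has been measured. Compound 4 is therefore estimated at 45%, with a range of 25% to 65%. The expected step is a number 17 percentage points lower from compound 3 to compound 4 (beyond the scatter).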

Compound 4, a percentage reported as inhibition, at one concentration (the size of the read-out at that concentration, not a potency): 18%
Estimate against measurement, compound 4: 27 percentage points above; the whole stated range lies above it.
By their numbers in this assay, from the lowest: compound 4; then compounds 1 and 3 (each within the scatter of the next); then compound 2.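

In this assay, methyl in place of phenyl on the amide-type nitrogen gives a number 44 percentage points lower from compound 3 to compound 4 (beyond the scatter), a large step, so the group on this nitrogen has a strong bearing on the number for the core of compound 3. Going by these compounds alone, the only earlier step at this nitrogen, a number 18 percentage points higher from compound 1 to compound 2 (beyond the scatter), was modest and belongs to the core of compound 1. No available evidence explains the size of the fall.

Still open, from the compounds shown here alone, is whether a cyclohexyl, a benzyl or an ethyl on this nitrogen would stay near compound 3 or fall towards compound 4.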